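A few compounds are considered here, and "the series" means these few. Any claim that something is new, unique, unknown or untested is made for them only; others in the source may bear on it.

Working notes on the series. Compound 1 `O=C(COc1cccc2ccccc12)N/N=C/c1cccc([N+](=O)[O-])c1` gives 61.2 ug/mL in an ADME assay on HEL cells (Homo sapiens) for cytotoxicity; on this read-out higher numbers stand for lower toxicity in this test and lower numbers for higher toxicity in this test; compound 2 `O=C(COc1cccc2ccccc12)N/N=C/c1ccccc1Cl` gives 62.7 ug/mL and compound 3 `O=C(COc1cccc2ccccc12)N/N=C/C=C/c1ccccc1` gives 100 ug/mL. Among these three numbers compound 3 sits at the top, yet its gaps to compound 2 and compound 1 both lie within the scatter, so no order can be read from them. Compound 4 `O=C(COc1cccc2ccccc12)N/N=C/c1cccc(Cl)c1` differs from compound 3 by 3-chlorophenyl in place of 2-phenylethenyl on a carbon with a double bond to nitrogen. Among the compounds with values here, the only measured step bearing on this exchange is a 1.6-fold higher number from compound 2 to compound 3 (0.20 log units; within the scatter), the reverse swap with 2-chlorophenyl rather than 3-chlorophenyl, and it stayed within the scatter. A step of no more than the scatter is therefore expected, a 1.5-fold lower number from compound 3 to compound 4 (0.19 log units; within the scatter), placing compound 4 near compound 2. Compound 4 is estimated at 65 ug/mL, with a range from 35 ug/mL to 100 ug/mL.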

Compound 4, half-maximal cytotoxic concentration: 58.6 ug/mL
Compound 4: middle estimate off by 1.1-fold (0.05 log units), on the high side; the measured number falls inside the stated range.
By their numbers in this assay, from the lowest: compounds 4, 1, 2 and 3 (each within the scatter of the next).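

In this assay, 3-chlorophenyl and 2-phenylethenyl on a carbon with a double bond to nitrogen stay within the scatter of each other (a 1.7-fold lower number from compound 3 to compound 4 (0.23 log units; within the scatter)). Within the data shown here, the new compound also gives the first direct reading of 3-chlorophenyl against 2-chlorophenyl (a 1.1-fold lower number from compound 2 to compound 4 (0.03 log units; within the scatter)) and of chloro against nitro on an aromatic carbon (a 1.0-fold lower number from compound 1 to compound 4 (0.02 log units; within the scatter)), and neither exchange separates the compounds. No supporting measurement bears on these steps. Going by these compounds, it remains open whether an amine or a carboxylic acid on the aromatic ring, or a longer chain in place of 2-phenylethenyl, would give a step beyond the scatter.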